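The source may report more compounds than this note shows. Statements on the series, on what has been measured and on what is new or still open speak of the compounds shown alone.

Measured so far in an ADME assay on microsomes from liver (Homo sapiens) for metabolic stability, read by LC-MS, tested at 0.5 uM; a higher number here means that the compound lasts longer, a lower number that the compound disappears faster:
compound 1, `Cc1nc(C)c([C@H](OC(C)(C)C)C(=O)O)c(N2CCC(C)(C)CC2)c1-c1ccc(OCCc2ccc(F)cc2F)cc1`: 1.08 h
compound 2, `Cc1nc(C)c([C@H](OC(C)(C)C)C(=O)O)c(N2CCC(C)(C)CC2)c1-c1ccc(CCCc2ccc(F)cc2)cc1`: > 2 h

Compound 2 stands at the ceiling of this assay; the figure reported for compound 2 is a limit and not a number, (the limit of > 2 h in this assay, at which 1 of the 2 values shown sits). Compound 3 is `Cc1nc(C)c([C@H](OC(C)(C)C)C(=O)O)c(N2CCC(C)(C)CC2)c1-c1ccc(OCCc2cccnc2)cc1` and differs from compound 2 in one place: 2-(pyridin-3-yl)ethoxy in place of 3-(4-fluorophenyl)propyl on an aromatic carbon. Among the measured compounds shown here, the only measured step, an at least 1.8-fold higher number from compound 1 to compound 2 (0.26 log units; that floor lies within the scatter), concerns a related exchange and its floor lies within scatter, so it bears on the change only loosely; compound 1 carries 2-(2,4-difluorophenyl)ethoxy on an aromatic carbon and gives a number in this assay. For compound 3 a step of an at least 1.5-fold lower number from compound 2 to compound 3 (0.18 log units; that floor lies within the scatter) is expected, a modest drop from the limit. The estimate for compound 3 is 1.3 h, within a range from 0.6 h to 2.5 h.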

Compound 3, half-life: 0.367 h
Estimate against measurement, compound 3: 3.5-fold (0.55 log units) above; measured number below the stated range.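

In this assay, 2-(pyridin-3-yl)ethoxy in place of 3-(4-fluorophenyl)propyl on this aromatic carbon gives an at least 5.4-fold lower number from compound 2 to compound 3 (0.73 log units; beyond the scatter), so this position can carry a change beyond the scatter. With the ethoxy chain unchanged, pyridin-3-yl in place of 2,4-difluorophenyl gives a 2.9-fold lower number from compound 1 to compound 3 (0.47 log units; beyond the scatter), so exchanging the ring alone already moves the half-life beyond the scatter. The figure for compound 2 is a limit, and the step from it has only a floor: the limit of > 2 h in this assay, at which 1 of the 3 values shown sits.

From the compounds shown here alone, what a plain phenyl or a pyridin-4-yl on the same chain would give stays open. So does the share of the drop that belongs to the chain oxygen rather than the ring.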